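The source may report more compounds than this note shows. Statements on the series, on what has been measured and on what is new or still open speak of the compounds shown alone.

Within the data shown here, in a functional assay on HeLa cells (Homo sapiens) for antiproliferative activity, read by CCK-8 assay, with a stated time of 72 h (on this read-out lower numbers stand for stronger inhibition and higher numbers for weaker inhibition), compound 1 (`Cc1ccc(Nc2nc(Cl)nc3c2ncn3Cc2ccc(C(=O)Nc3ccccc3N)cc2)cc1`) gives 1050 nM, the lower of the two numbers available so far. Compound 2 (`Nc1ccccc1NC(=O)c1ccc(CNc2nc(Cl)nc3c2ncn3C2CCCC2)cc1`) gives 3020 nM, a number beyond the scatter from the first. Compound 3 (`CC1CCN(c2nc(Cl)nc3c2ncn3Cc2ccc(C(=O)Nc3ccccc3N)cc2)CC1`) keeps the core of compound 1 but carries 4-methylpiperidin-1-yl in place of (4-methylphenyl)amino on an aromatic carbon. Among the measured compounds shown here, no measured pair isolates this change, so only a moderate rise in the number, meaning weaker inhibition, is expected in this assay. The estimated step runs a 2.1-fold higher number from compound 1 to compound 3 (0.32 log units; beyond the scatter). The estimate for compound 3 is 2200 nM, with an expected range from 700 nM to 7000 nM.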

Compound 3, half-maximal inhibitory concentration: 4500 nM
Compound 3: middle estimate off by 2.0-fold (0.31 log units), on the low side, within the range that was stated.
By their numbers in this assay, from the lowest: compound 1; then compounds 2 and 3 (each within the scatter of the next).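

Compound 1 and compound 3 differ in one place only, and in this assay 4-methylpiperidin-1-yl in place of (4-methylphenyl)amino on this aromatic carbon gives a 4.3-fold higher number from compound 1 to compound 3 (0.63 log units; beyond the scatter), a modest loss of inhibition. So this position responds to the group it carries, which compound 1 and compound 2 alone could not show. Nothing available bears on the cause of this rise.

Still open, going by these compounds, is how morpholin-4-yl or a phenylamino group without the methyl would read at this position. On these data alone, it is also open whether this step would hold in a compound carrying the cyclopentyl group of compound 2.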